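Oxindole hydrazone carboxamides and thiocarboxamides: cytotoxicity notes

The compounds below may be only part of what the source reports. "The series", "measured", "known", "first", "only" and "open" are said of these compounds alone.

Measured so far:
compound 1 `COc1cccc(NC(=O)N/N=C2\C(=O)Nc3ccccc32)c1`, > 25000 nM
compound 2 `O=C(N/N=C1\C(=O)Nc2ccccc21)Nc1ccccc1`, > 25000 nM
compound 3 `O=C1Nc2ccccc2/C1=N/NC(=S)Nc1ccccc1`, > 25000 nM

In an ADME assay on RD cells (Homo sapiens) for cytotoxicity (on this read-out higher numbers stand for lower toxicity in this test and lower numbers for higher toxicity in this test), compound 1 reaches only a limit, > 25000 nM. Compound 2 likewise gives only a limit in this assay, > 25000 nM. Compound 3 too shows a limit in this assay, > 25000 nM. The step that the two limits leave unreadable from compound 2 to compound 1 is the change (methoxy in place of hydrogen on an aromatic carbon); because both ends are limits (the limit of > 25000 nM in this assay, at which 3 of the 3 values shown sit), its size cannot be read. The difference between the cores of compound 3 and compound 2 is not broken down here.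

Compound 4 `COc1ccccc1NC(=S)N/N=C1\C(=O)Nc2ccccc21` is not yet measured. It differs from compound 3 by methoxy in place of hydrogen on an aromatic carbon, the same kind of change as that from compound 2 to compound 1, though the place differs: meta to a large group there, ortho to a large group here. Given that compound 3 sits at a limit > 25000 nM and that the limit of > 25000 nM in this assay, at which 3 of the 3 values shown sit, holds for all three measured compounds, compound 4 is expected to remain at or beyond that limit, an estimated step that the limit leaves unreadable from compound 3 to compound 4. The estimate for compound 4 in this assay is 40000 nM, ranging from 15000 nM to 120000 nM.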

Compound 4, half-maximal cytotoxic concentration: > 25000 nM
Compound 4: no number, only a limit; the forecaster's own chance of this, stated with the estimate: 85%; the middle value is on the limit's open side.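

Compound 3 and compound 4 both stand at limits, so no new step can be read between them: the limit of > 25000 nM in this assay, at which 4 of the 4 values shown sit.

The compounds shown leave open how far any of them lies beyond that limit in this assay.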